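The source may hold more compounds than are shown below. What is called first, only, known or untested is meant among the compounds shown, and "the series" means these compounds.

Two measured compounds share a core that carries a urea linked through a hydrazone to a substituted phenyl ring. Compound 1 `CN(C)CCn1cnnc1-c1cc(Oc2ccc(NC(=O)N/N=C/c3ccccc3O[N+](=O)[O-])cc2F)ccn1` bears a 2-(nitrooxy)phenyl on the carbon with a double bond to nitrogen; in an ADME assay on WI-38 cells (Homo sapiens) for cytotoxicity, read by MTT assay, with a stated time of 72 h (on this read-out higher numbers stand for weaker inhibition and lower numbers for stronger inhibition), compound 1 gives 6860 nM. Compound 2 `COc1cc(/C=N/NC(=O)Nc2ccc(Oc3ccnc(-c4nncn4CCN(C)C)c3)c(F)c2)ccc1O` carries a 4-hydroxy-3-methoxyphenyl at the same place, and in this assay compound 2 gives 5320 nM. Among the compounds with values here, the only measured step, a 1.3-fold lower number from compound 1 to compound 2 (0.11 log units; within the scatter), leaves both numbers within the scatter of each other, so compound 2 stands as the lower of the two numbers without any real separation from compound 1.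

Compound 3 `Cc1cc(/C=N/NC(=O)Nc2ccc(Oc3ccnc(-c4nncn4CCN(C)C)c3)c(F)c2)cc(C)c1O` has not yet been measured. It differs from compound 2 by 4-hydroxy-3,5-dimethylphenyl in place of 4-hydroxy-3-methoxyphenyl on a carbon with a double bond to nitrogen. Within the data shown here, the one step that bears on this change, a 1.3-fold lower number from compound 1 to compound 2 (0.11 log units; within the scatter), exchanged the whole ring at this position and produced no shift beyond the scatter; a swap of methoxy for methyl groups on a ring that keeps its hydroxyl is a smaller change still. Compound 3 is therefore expected to give a step of a 1.0-fold higher number from compound 2 to compound 3 (0.01 log units; within the scatter), that is none beyond the scatter. The estimate for compound 3 in this assay is 5500 nM, with a range from 2500 nM to 12000 nM.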

Compound 3, half-maximal inhibitory concentration: 3610 nM
For compound 3 the middle estimate is 1.5-fold (0.18 log units) above the measured one; the measured number falls inside the stated range.
By their numbers in this assay, from the lowest: compounds 3, 2 and 1 (each within the scatter of the next).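

In this assay, the methoxy-to-methyl exchange on a ring that keeps its hydroxyl gives a 1.5-fold lower number from compound 2 to compound 3 (0.17 log units; within the scatter) and so stays inside the scatter, which means this change on the carbon with a double bond to nitrogen has no effect that can be told apart from repeat variation. The wider exchange, 4-hydroxy-3,5-dimethylphenyl in place of 2-(nitrooxy)phenyl, gives a 1.9-fold lower number from compound 1 to compound 3 (0.28 log units; within the scatter) and is also printed as within the scatter, so all three groups at this place now read alike in this cell assay, and the earlier finding of no separation holds for a third substituted phenyl ring. No supporting measurement accompanies these numbers that could account for the small differences among the three compounds.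

The compounds shown leave open whether an amine or a carboxylic acid on this phenyl ring would move the number beyond the scatter, since every group so far carries only oxygen-linked or methyl substituents, apart from the nitrogen of the nitrooxy group. They also leave open whether a longer alkyl chain on the ring, such as a propyl or butyl group, would read any differently from the methyl groups of compound 3.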